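The source may hold more compounds than are shown below. What is called first, only, known or untested is meant among the compounds shown, and "the series" means these compounds.

Compound 3, `O=C1OC(c2ccc(Cl)cc2)=C/C1=C\c1ccc(F)cc1`, stands highest of the three numbers measured in a functional assay on the whole organism (strain Wistar) for inhibition, with Rattus norvegicus as the target, with stated times of 30 min and 3 h, at a dose of 20 mg/kg by the oral route (on this read-out higher numbers stand for more inhibition at the one dose given (going by the name of the read-out) and lower numbers for less inhibition), where compound 3 gives 70.4%. Its nearest neighbour is compound 2, `O=C1OC(c2ccc(Cl)cc2)=C/C1=C\c1ccc(Cl)cc1`, which in this assay gives 69.1%, a value within the scatter of that of compound 3, so the two cannot be ranked against each other. Furthest away is compound 1, `O=C1OC(c2ccc(Cl)cc2)=C/C1=C\c1ccccc1`, which in this assay gives 36%, a gap well beyond the scatter. The unmeasured compound 4, `COc1ccc(/C=C2\C=C(c3ccc(Cl)cc3)OC2=O)cc1`, differs from compound 3 in one place: methoxy in place of fluoro on an aromatic carbon. Two kinds of measured step bear on this change. Placing fluoro in place of hydrogen gave a number 34.4 percentage points higher from compound 1 to compound 3 (beyond the scatter), and placing chloro in place of hydrogen gave a number 33.1 percentage points higher from compound 1 to compound 2 (beyond the scatter), so filling this aromatic carbon with a group went with a large rise in both cases. Exchanging one halogen for another gave a number 1.3 percentage points higher from compound 2 to compound 3 (within the scatter), a step within the scatter. Going by the values given here, no methoxy-bearing compound has been measured, so whether methoxy behaves like the halogens at this position is unknown. The expected step is therefore a number 8.4 percentage points lower from compound 3 to compound 4 (within the scatter), not beyond the scatter. The estimate for compound 4 in this assay is 62%, with a range from 40% to 80%.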

Compound 4, a percentage reported as inhibition, in the whole organism at one dose (the size of the read-out at that dose, not a potency): 32.3%
Estimate against measurement, compound 4: 29.7 percentage points above; the whole stated range lies above it.
By their numbers in this assay, from the lowest: compounds 4 and 1 (each within the scatter of the next); then compounds 2 and 3 (each within the scatter of the next).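

In this assay, what this aromatic carbon carries matters by its kind and not only by being filled: methoxy in place of fluoro gives a number 38.1 percentage points lower from compound 3 to compound 4 (beyond the scatter) and methoxy in place of chloro gives a number 36.8 percentage points lower from compound 2 to compound 4 (beyond the scatter), so two large steps now run downward at a spot where earlier changes had only shown large rises. Methoxy in place of hydrogen gives a number 3.7 percentage points lower from compound 1 to compound 4 (within the scatter), which means the methoxy compound cannot be told apart from the compound with plain hydrogen there, and the rise seen with fluoro and chloro does not extend to every group placed on this carbon. No measurement at hand explains why methoxy parts from the two halogens here.

Going by these compounds, only hydrogen, fluoro, chloro and methoxy appear at this carbon, so it stays open whether a methyl, a hydroxy, a trifluoromethyl or an amine would fall with the two halogens or with methoxy and hydrogen. Also open, on these data alone, is how changes would play out on the other aromatic ring, which carries chloro in all four compounds.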